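Chalcone dithiocarbamates: aryl swap on the enone terminus

The source may report more compounds than this note shows. Statements on the series, on what has been measured and on what is new or still open speak of the compounds shown alone.

Compound 2 `O=C(/C=C/c1cccs1)c1ccc(OCCSC(=S)N2CCCC2)cc1` gives 19100 nM in a functional assay on SK-N-SH cells (Homo sapiens) for inhibition, read by MTT assay, with a stated time of 72 h (on this read-out lower numbers stand for stronger inhibition and higher numbers for weaker inhibition), the lowest of the three numbers recorded, though compound 3 `COc1ccc(/C=C/C(=O)c2ccc(OCCCSC(=S)N3CCN(C)CC3)cc2)cc1` with 29500 nM and compound 1 `CN1CCN(C(=S)SCCCOc2ccc(C(=O)/C=C/c3ccc(Cl)cc3)cc2)CC1` with 31900 nM both lie within the scatter of it. Among the compounds with values here, the only measured single-point step, a 1.1-fold lower number from compound 1 to compound 3 (0.03 log units; within the scatter), concerns a substituent on the distal ring and does not touch the ring itself. Compound 4 `O=C(/C=C/c1ccc(Cl)cc1)c1ccc(OCCSC(=S)N2CCCC2)cc1` differs from compound 2 by 4-chlorophenyl in place of thiophen-2-yl on a double-bonded chain carbon bound to a double-bonded chain carbon. Within the data shown here, no measured pair isolates this ring exchange; compound 1 carries the same 4-chlorophenyl group on a different core and sits within the scatter of compound 2. Compound 4 is therefore expected to show a 1.2-fold higher number from compound 2 to compound 4 (0.08 log units; within the scatter), no step beyond the scatter, with an estimated 23000 nM (range 9000 nM to 60000 nM).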

Compound 4, half-maximal inhibitory concentration: 18300 nM
Estimate against measurement, compound 4: 1.3-fold (0.10 log units) above; the measured number falls inside the stated range.
By their numbers in this assay, from the lowest: compounds 4, 2, 3 and 1 (each within the scatter of the next).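

In this assay, within the data shown here, the ring itself is exchanged for the first time, and this gives a 1.0-fold lower number from compound 2 to compound 4 (0.02 log units; within the scatter). The earlier step changed only a substituent on the distal ring, whereas this one shows that thiophen-2-yl and 4-chlorophenyl are not told apart on the core shared by compound 2 and compound 4. Nothing measured here offers an explanation of this result.

From the compounds shown here alone, it remains open whether furan-2-yl, or a phenyl ring bearing a carboxylic acid, would give a step beyond the scatter at this place. Going by these compounds, it is also open whether the same ring exchange reads alike on the core of compound 1.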